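The source may report more compounds than this note shows. Statements on the series, on what has been measured and on what is new or still open speak of the compounds shown alone.

Measured so far:
- Compound 1, `Cc1cccc2sc(NC(=O)COc3ccc(/C=C4\SC(=O)NC4=O)cc3)nc12`: 45800 nM
- Compound 2, `O=C(COc1ccc(/C=C2\SC(=O)NC2=O)cc1)Nc1cccc([N+](=O)[O-])c1`: 20500 nM

Both compounds were tested in a functional assay on K562 cells (Homo sapiens) for inhibition; on this read-out higher numbers stand for weaker inhibition of growth and lower numbers for stronger inhibition of growth. Of the two numbers, compound 2 gives the lower one with 20500 nM, while compound 1 gives 45800 nM, and the gap between them is beyond the usual scatter of repeated measurements. Compound 2 is therefore the stronger growth inhibitor of the two, although both numbers are high and stand for weak inhibition.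

Compound 3, `O=C(COc1ccc(/C=C2\SC(=O)NC2=O)cc1)Nc1ccc(Br)cc1`, has not yet been measured. It keeps the shared core of compound 2 and differs in one place: 4-bromophenyl in place of 3-nitrophenyl on an amide-type nitrogen. For the measured compounds named here, no pair of measured compounds shows a change of this kind, so the size of the step cannot be read from any earlier comparison. With nothing to point in either direction, the step is expected to stay within the scatter, and the estimated step is a 1.2-fold higher number from compound 2 to compound 3 (0.09 log units; within the scatter). On that basis compound 3 is expected to give about 25000 nM in this assay, with a plausible range from 8000 nM to 80000 nM.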

Compound 3, concentration for 50% growth inhibition: 23400 nM
Compound 3: middle estimate off by 1.1-fold (0.03 log units), on the high side, within the range that was stated.
By their numbers in this assay, from the lowest: compounds 2, 3 and 1 (each within the scatter of the next, the first and the last beyond it).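

In this assay, placing 4-bromophenyl in place of 3-nitrophenyl on the amide-type nitrogen gives a 1.1-fold higher number from compound 2 to compound 3 (0.06 log units; within the scatter), so this exchange leaves growth inhibition unchanged within the scatter. The exchange is not a small one on paper: both groups hold one six-membered aromatic ring of carbon only, but the leaving group counts 2 hydrogen-bond acceptors and the entering group 0, and the substituent also sits at a different ring position, as the two names show. Even so, the read-out does not separate the two compounds, although a single pair cannot show how far this holds for other groups at this position, and no measurement is available that would explain the result.

Both groups shown on this nitrogen are substituted phenyl rings, so it remains open whether a group without an aromatic ring, such as a longer alkyl chain, would keep this level of growth inhibition. On these data alone, it also remains open whether an amine or a carboxylic acid on the phenyl ring would shift the number beyond the scatter.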